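The source may report more compounds than this note shows. Statements on the series, on what has been measured and on what is new or still open speak of the compounds shown alone.

Three compounds have been measured so far in a functional assay on SMMC-7721 cells (Homo sapiens) for cytotoxicity, read by MTT assay, with a stated time of 24 h; on this read-out lower numbers stand for stronger inhibition and higher numbers for weaker inhibition:

compound 1, `Cc1ccc(S(=O)(=O)N2C/C(=C\c3cccc(F)c3)C(=O)/C(=C/c3cccc(F)c3)C2)cc1`, gives 18100 nM;
compound 2, `O=C1/C(=C/c2cccc(F)c2)CN(S(=O)(=O)c2ccc(F)cc2)C/C1=C\c1cccc(F)c1`, gives 13500 nM;
compound 3, `N#Cc1ccc(S(=O)(=O)N2C/C(=C\c3cccc(F)c3)C(=O)/C(=C/c3cccc(F)c3)C2)cc1`, gives 4500 nM.

Compound 3 stands lowest of the three. The steps of a 4.0-fold lower number from compound 1 to compound 3 (0.60 log units; beyond the scatter) and a 3.0-fold lower number from compound 2 to compound 3 (0.48 log units; beyond the scatter) both lie beyond the scatter, whereas a 1.3-fold lower number from compound 1 to compound 2 (0.13 log units; within the scatter) stays within it. Compound 4, `CC(=O)Nc1ccc(S(=O)(=O)N2C/C(=C\c3cccc(F)c3)C(=O)/C(=C/c3cccc(F)c3)C2)cc1`, differs from compound 3 in a single place: acetamido in place of cyano on an aromatic carbon. Among the measured compounds shown here, the steps that bear on this change are the two that exchanged the group on the same aromatic carbon, since both ended at compound 3 and both were modest. For the measured compounds named here, no measured compound carries an acetamido group, so the direction cannot be read directly from the data; what the three measured swaps show is that exchanging this group shifts the number only modestly. A modest step upward, back toward the numbers of compound 1 and compound 2, is therefore expected, a 2.0-fold higher number from compound 3 to compound 4 (0.30 log units; within the scatter). Compound 4 is estimated at 9000 nM, with a range from 3500 nM to 25000 nM.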

Compound 4, half-maximal inhibitory concentration: 10300 nM
Compound 4: the middle estimate sits 1.1-fold (0.06 log units) below what was measured, and the stated range covers the measured number.
By their numbers in this assay, from the lowest: compound 3; then compounds 4, 2 and 1 (each within the scatter of the next).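

Set against the nitrile of compound 3, the acetamido group, which unlike cyano carries a hydrogen-bond donor, gives a step beyond the scatter in this assay: a 2.3-fold higher number from compound 3 to compound 4 (0.36 log units; beyond the scatter). Against the other two groups it stays within the scatter, with a 1.3-fold lower number from compound 2 to compound 4 (0.12 log units; within the scatter) and a 1.8-fold lower number from compound 1 to compound 4 (0.24 log units; within the scatter), so methyl, fluoro and acetamido cannot be told apart at this position, and only cyano stands apart from the rest. Nothing available here accounts for this difference between cyano and the other three groups.

Still open, on these data alone, is whether this standing belongs to cyano alone or would be shared by another group on this aromatic carbon, such as a carboxylic acid, an amine or trifluoromethyl. An acetamido group with methyl in place of the amide hydrogen would show whether that hydrogen matters at all.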